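The source may hold more compounds than are shown below. What is called first, only, known or untested is meant among the compounds shown, and "the series" means these compounds.

In a functional assay on the whole organism (artery, strain albino) with Rattus norvegicus as the target, with a stated time of 600 min, at a dose of 10 mg/kg by the oral route (on this read-out higher numbers stand for more inhibition at the one dose given (going by the name of the read-out) and lower numbers for less inhibition), three compounds have been measured so far:

Compound 1 `CC1=C(C(=O)Nc2ccc(Br)cc2)C(c2ccc(Cl)cc2Cl)N=C(SCc2ccccc2Cl)N1`: 24.6%
Compound 2 `CC1=C(C(=O)Nc2ccc(Br)cc2)C(c2ccc(Cl)cc2Cl)N=C(SCc2cccc(Cl)c2)N1`: 15.4%
Compound 3 `CC1=C(C(=O)Nc2ccc(Br)cc2)C(c2ccc(Cl)cc2Cl)N=C(SCc2ccc(F)cc2)N1`: 33.3%

Compound 2 gives the smallest of the three numbers. Its gap to compound 1, a number 9.2 percentage points lower from compound 1 to compound 2 (within the scatter), lies within the scatter, so these two cannot be told apart on this read-out. Its gap to compound 3, a number 17.9 percentage points higher from compound 2 to compound 3 (beyond the scatter), goes beyond the scatter and counts as a modest step. The remaining comparison, a number 8.7 percentage points higher from compound 1 to compound 3 (within the scatter), is again within the scatter.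

Compound 4 `COc1ccc(C2N=C(SCc3cccc(Cl)c3)NC(C)=C2C(=O)Nc2ccc(Br)cc2)cc1` has not yet been measured in this assay. It differs from compound 2 in a single place: 4-methoxyphenyl in place of 2,4-dichlorophenyl on a saturated ring carbon. All three measured steps change the phenyl on a saturated chain carbon bound to a sulfur; none of them touches the group on the saturated ring carbon. Among the measured compounds shown here, the measured data therefore contain no step that bears on this change, and nothing indicates the direction or size of any shift. In that situation the step from compound 2 to compound 4 is expected to be a number 0.4 percentage points lower from compound 2 to compound 4 (within the scatter), that is, nothing beyond the scatter is expected. Compound 4 is accordingly estimated at 15%, with a range from 2% to 35%.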

Compound 4, a percentage reported as inhibition, in the whole organism at one dose (the size of the read-out at that dose, not a potency): 32.8%
Estimate against measurement, compound 4: 17.8 percentage points below; low and high end bracket the measured number.
By their numbers in this assay, from the lowest: compounds 2, 1, 4 and 3 (each within the scatter of the next, the first and the last beyond it).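

In this assay, among the compounds shown here, the group on the saturated ring carbon, which no earlier step had touched, proves able to move the read-out: 4-methoxyphenyl in place of 2,4-dichlorophenyl gives a number 17.4 percentage points higher from compound 2 to compound 4 (beyond the scatter) and so counts as a modest step. The change also leaves the heavy-atom count of the group the same, with 8 on each side, while chlorine gives way to carbon and oxygen and the entering group has 1 hydrogen-bond acceptor where the leaving group has 0. No measurement at hand accounts for the step or shows which of these differences carries it.

The compounds shown leave open whether the step comes from the methoxy group entering or from the two chlorines leaving, a question that a plain phenyl or a 4-chlorophenyl on the same ring carbon could help to settle. From the compounds shown here alone, they also rest on a single pair, so it remains open whether the same change has a similar effect when the sulfur carries the 4-fluorophenyl-bearing chain of compound 3.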